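This account rests on a few compounds, and the source may have more. Where it says the series, first, only, none or still open, it means among the compounds named here.

In a functional assay on CAKI-1 cells (Homo sapiens) for inhibition, read by sulforhodamine B assay, with a stated time of 48 h (a higher number here means a weaker inhibitor of growth, a lower number a stronger inhibitor of growth), the three measured compounds stand as follows:

Compound 1 `COc1cc(-c2nn(-c3cccc(NC(=O)Nc4cc(C(F)(F)F)cc(C(F)(F)F)c4)c3)cc2-c2ccncc2)ccc1Cl`: 993 nM
Compound 2 `COc1cc(-c2nn(-c3cccc(NC(=O)Nc4ccc(Cl)c(Cl)c4)c3)cc2-c2ccncc2)ccc1Cl`: 1120 nM
Compound 3 `O=C(Nc1cccc(-n2cc(-c3ccncc3)c(-c3ccc(Cl)c(O)c3)n2)c1)Nc1ccc(Cl)c(Cl)c1`: 1110 nM

Compound 2 carries the highest of the three numbers, yet its gap to compound 3 a 1.0-fold lower number from compound 2 to compound 3 (0.00 log units; within the scatter) and its gap to compound 1 are both within the scatter, so the three compounds cannot be separated on these data.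

Compound 4 `COc1cc(-c2nn(-c3cccc(NC(=O)c4ccc(Cl)c(C(F)(F)F)c4)c3)cc2-c2ccncc2)ccc1Cl` is not yet measured. It differs from compound 2 in one place: 4-chloro-3-(trifluoromethyl)phenyl in place of (3,4-dichlorophenyl)amino on a carbonyl carbon. For the measured compounds named here, no measured step touches this position. Going by the values given here, the one step that is known, from compound 2 to compound 3, concerns the oxygen on an aromatic ring elsewhere in the shared core and was flat. Compound 1 and compound 2 differ in the aryl group that leaves in this change, and their two values show no difference beyond the scatter, which suggests that this part of the molecule has so far tolerated variation without a shift in the numbers.

Among the compounds with values here, on that basis, and with no direct precedent for the change at the carbonyl carbon, compound 4 is expected to land close to compound 2, with the step from compound 2 to compound 4 a 1.0-fold lower number from compound 2 to compound 4 (0.01 log units; within the scatter) estimated to stay within the scatter. The estimate for compound 4 in this assay is 1100 nM, with a range of 400 nM to 3200 nM.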

Compound 4, concentration for 50% growth inhibition: 2300 nM
For compound 4 the middle estimate is 2.1-fold (0.32 log units) below the measured one; low and high end bracket the measured number.
By their numbers in this assay, from the lowest: compounds 1, 3 and 2 (each within the scatter of the next); then compound 4.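

In this assay, for the compounds shown here, this position does respond to change: replacing (3,4-dichlorophenyl)amino with 4-chloro-3-(trifluoromethyl)phenyl on the carbonyl carbon gives a 2.1-fold higher number from compound 2 to compound 4 (0.31 log units; beyond the scatter) and so moves the number modestly, whereas the only earlier step, a 1.0-fold lower number from compound 2 to compound 3 (0.00 log units; within the scatter) at the oxygen on an aromatic ring elsewhere in the shared core, stayed flat. Compound 4 therefore shows that variation here is not tolerated without limit, and it places a higher number on a swap in which the hydrogen-bond donor count of the group falls from 1 to 0 and the heavy-atom count rises. The data shown contain no separate measurement that would account for this shift.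

The change removes the amino nitrogen and exchanges a chlorine for a trifluoromethyl group in a single step, so these compounds leave open which of the two goes with the higher number. A (4-chloro-3-(trifluoromethyl)phenyl)amino group or a 3,4-dichlorophenyl group on the same carbonyl carbon would separate them, while a methylene in place of the amino nitrogen remains a further open case.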